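Acetoxy for methanesulfonamido on the pyrrolidine: stability

The source may hold more compounds than are shown below. What is called first, only, known or untested is meant among the compounds shown, and "the series" means these compounds.

Of the compounds shown here, two sharing one core have been tested in an ADME assay on microsomes from liver (Homo sapiens) for metabolic stability, read by LC-MS, with NADPH named in the record, with a stated time of 60 min, tested at 1 uM, in the absence of a further agent; on this read-out higher numbers stand for a more stable compound and lower numbers for a less stable compound. Compound 1, `CC(=O)N[C@@H]1CCN(c2cc(C)nn3c(-c4ccc(C(F)(F)F)cc4)c(C)nc23)C1`, is reported only as a limit of the assay: in this assay compound 1 gives > 95%. Compound 2, `COc1ccc(-c2c(C)nc3c(N4CC[C@@H](NS(C)(=O)=O)C4)cc(C)nn23)cc1OC`, likewise reaches a limit: in this assay compound 2 gives > 95%. Both results therefore sit at the same edge of what the assay can report, as noted in the limit of > 95% in this assay, at which 2 of the 2 values shown sit, and neither can be placed above the other.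

Compound 3, `COc1ccc(-c2c(C)nc3c(N4CC[C@@H](OC(C)=O)C4)cc(C)nn23)cc1OC`, has not yet been measured. It differs from compound 2 in one place: acetoxy in place of methanesulfonamido on a saturated ring carbon. Going by the values given here, no measured pair in this set shows the effect of such a change, so any expectation rests on the step itself. A drop in this assay is expected, likely beyond the usual scatter, so that the step of a number at least 17 percentage points lower from compound 2 to compound 3 (beyond the scatter) points downward. Compound 3 is estimated at 78%, within 50% to 95%.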

Compound 3, percent of the compound remaining: > 95%
Compound 3: only a limit was reported; the forecaster's own chance of this, stated with the estimate: 30%; at least 17 percentage points between middle value and limit.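

In this assay compound 3 gives > 95% as a limit of the assay, so no step from compound 2 to compound 3 can be read: the limit of > 95% in this assay, at which 3 of the 3 values shown sit.

The compounds shown leave open how far their true stability differs, and whether swapping methanesulfonamido for acetoxy changes it at all.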